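Notes on replacing the 4-nitrophenyl group

A few compounds are considered here, and "the series" means these few. Any claim that something is new, unique, unknown or untested is made for them only; others in the source may bear on it.

Measured in a functional assay on SMMC-7721 cells (Homo sapiens) for cytotoxicity, read by MTT assay, with a stated time of 24 h; on this read-out higher numbers stand for weaker inhibition and lower numbers for stronger inhibition:
- compound 1 `CN1C/C(=C\c2cccnc2)C(=O)/C(=C/c2ccccc2F)C1`: 5420 nM
- compound 2 `Cc1ccc(S(=O)(=O)N2C/C(=C\c3cccnc3)C(=O)/C(=C/c3ccccc3F)C2)cc1`: 10300 nM
- compound 3 `O=C1/C(=C/c2cccnc2)CN(S(=O)(=O)c2ccc([N+](=O)[O-])cc2)C/C1=C\c1ccccc1F`: > 20000 nM (a limit, not a number)

Compound 3 has only a limit in this assay, and (the limit of > 20000 nM in this assay, at which 1 of the 3 values shown sits).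

Compound 4 `O=C1/C(=C/c2cccnc2)CN(S(=O)(=O)c2ccc(F)cc2)C/C1=C\c1ccccc1F` carries fluoro in place of nitro on an aromatic carbon, para to a large group: fluoro in place of nitro on an aromatic carbon.

The closest measured change is an at least 1.9-fold higher number from compound 2 to compound 3 (0.28 log units; that floor lies within the scatter), which also involves the nitro group. The step of a 1.9-fold higher number from compound 1 to compound 2 (0.28 log units; within the scatter) bears on it less directly, as it changes the group on the ring nitrogen. Removing nitro is expected to give a lower number, near compound 2 at 10300 nM.

The expected step is an at least 1.8-fold lower number from compound 3 to compound 4 (0.25 log units; that floor lies within the scatter).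

For compound 4 the estimated value is 11000 nM, with an expected range of 5000 nM to 24000 nM.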

Compound 4, half-maximal inhibitory concentration: 9900 nM
For compound 4 the middle estimate is 1.1-fold (0.05 log units) above the measured one, and the stated range covers the measured number.
By their numbers in this assay, from the lowest: compounds 1, 4 and 2 (each within the scatter of the next). At a limit, above all of these: compound 3.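

In this assay compound 3, with its 4-nitrophenyl group, has only a limit and not a number: the limit of > 20000 nM in this assay, at which 1 of the 4 values shown sits. Fluoro in place of nitro gives a measured value, but only a floor is known for this change (an at least 2.0-fold lower number from compound 3 to compound 4 (0.30 log units; that floor lies within the scatter)). Fluoro and methyl on this aromatic carbon are not separated (a 1.0-fold lower number from compound 2 to compound 4 (0.02 log units; within the scatter)), and the (4-fluorophenyl)sulfonyl group on the ring nitrogen is not separated from methyl there either (a 1.8-fold higher number from compound 1 to compound 4 (0.26 log units; within the scatter)).

Open, from the compounds shown here alone, is what an amine or a methoxy on the same aromatic carbon would give. Also open, going by these compounds, is whether any group there moves the number beyond the scatter of compound 2 and compound 4.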